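The compounds below may be only part of what the source reports. "The series", "measured", "known", "first", "only" and "open" are said of these compounds alone.

Compound 1 `Cc1cc(C)c(Oc2cc(Nc3ccc(C#N)cc3)ncc2C(=O)NCc2cn(Cc3ccccc3F)nn2)c(C)c1` in an ADME assay on MT4 cells (Homo sapiens) for cytotoxicity, read by MTT assay, with a stated time of 5 days (a higher number here means that more compound is tolerated, a lower number that less compound is tolerated), gives > 222000 nM, a limit of the assay.
Compound 2 `Cc1cc(C)c(Oc2cc(Nc3ccc(C#N)cc3)ncc2C(=O)NCc2cn(Cc3cccc(C#N)c3)nn2)c(C)c1` in this assay gives >= 129000 nM, also a limit of the assay.
Compound 3 `CCOC(=O)CCn1cc(CNC(=O)c2cnc(Nc3ccc(C#N)cc3)cc2Oc2c(C)cc(C)cc2C)nn1` in this assay gives 21500 nM.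

Within the data shown here, compound 3 thus holds the only real number among the three; compound 1 sits at the limit of > 222000 nM in this assay, at which 1 of the 3 values shown sits, and compound 2 at the limit of >= 129000 nM in this assay, at which 1 of the 3 values shown sits. Compound 4 `Cc1cc(C)c(Oc2cc(Nc3ccc(C#N)cc3)ncc2C(=O)NCc2cn(CC(=O)N3CCOCC3)nn2)c(C)c1` differs from compound 3 by (morpholin-4-yl)carbonyl in place of (ethoxycarbonyl)methyl on a saturated chain carbon bound to an aromatic nitrogen. Among the measured compounds shown here, two measured steps touch this position: an at least 10-fold lower number from compound 1 to compound 3 (1.01 log units; beyond the scatter) and an at least 6.0-fold lower number from compound 2 to compound 3 (0.77 log units; beyond the scatter), both arriving at the ester that compound 4 now gives up. For the measured compounds named here, neither tests the morpholine amide itself, and no measured step leaves the ester for another chain. Only a small step is therefore expected, a 1.4-fold higher number from compound 3 to compound 4 (0.14 log units; within the scatter). Compound 4 is estimated at 30000 nM, between 10000 nM and 100000 nM.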

Compound 4, half-maximal cytotoxic concentration: 181000 nM
Compound 4: the middle estimate sits 6.0-fold (0.78 log units) below what was measured, outside the stated range (above it).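

In this assay, among these compounds, moving from (ethoxycarbonyl)methyl to (morpholin-4-yl)carbonyl gives an 8.4-fold higher number from compound 3 to compound 4 (0.93 log units; beyond the scatter), the first measured step that leaves the ester, and it shows that this position can recover from the ester's low number without an aromatic ring on the chain. Against the 2-fluorophenyl compound there is an at least 1.2-fold lower number from compound 1 to compound 4 (0.08 log units; that floor lies within the scatter), whose floor lies within the scatter, and the step between compound 2 and compound 4 cannot be read. Compound 1 gives a limit, not a number: the limit of > 222000 nM in this assay, at which 1 of the 4 values shown sits.

The same change turns 2-(ethoxycarbonyl)ethyl into ((morpholin-4-yl)carbonyl)methyl, so chain length and end group move together and cannot be told apart. From the compounds shown here alone, what a carboxylic acid, or a longer chain carrying the morpholine amide, would give at this position stays open.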